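This account rests on a few compounds, and the source may have more. Where it says the series, first, only, none or still open, it means among the compounds named here.

Measured compounds:
compound 1 `O=[N+]([O-])c1ccc2[nH]c(-c3ccc(-c4ccccc4)cc3)nc2c1` gives 4880 nM
compound 2 `NCc1ccc(-c2ccc(-c3nc4cc(C(F)(F)F)ccc4[nH]3)cc2)cc1` gives 720 nM

Both numbers come from a functional assay for antagonist activity at Neuropeptides B/W receptor type 1 (Homo sapiens), read by cAMP accumulation; a higher number here means a weaker inhibitor, a lower number a stronger inhibitor. In this assay compound 1 stands at the higher of the two numbers shown; the nearest comparison is compound 2, and the gap between the two values lies beyond the usual scatter, so compound 2 is the stronger inhibitor of the pair. Compound 2 differs from compound 1 in more than one place, so the two values show only that and nothing about any single change.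

Compound 3 `CC(C)(C)c1ccc(-c2nc3cc([N+](=O)[O-])ccc3[nH]2)cc1` has not been measured. It differs from compound 1 in one place: tert-butyl in place of phenyl on an aromatic carbon. Going by the values given here, no measured pair shows this change, so there is no step to lean on. The author expects the step from compound 1 to compound 3 to be small, in no clear direction and within the scatter, which is what a 1.2-fold lower number from compound 1 to compound 3 (0.09 log units; within the scatter) is meant to express. For compound 3 the estimate in this assay is 4000 nM, with a range from 1500 nM to 12000 nM.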

Compound 3, half-maximal inhibitory concentration: 3180 nM
For compound 3 the middle estimate is 1.3-fold (0.10 log units) above the measured one, and the stated range covers the measured number.
By their numbers in this assay, from the lowest: compound 2; then compounds 3 and 1 (each within the scatter of the next).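

In this assay, putting tert-butyl in place of phenyl on this aromatic carbon, para to a large group, gives a 1.5-fold lower number from compound 1 to compound 3 (0.19 log units; within the scatter) and so leaves the reading unresolved from that of the parent. Going by these compounds alone, this is the first view of this position alone, since compound 2 differs from compound 1 in more than one place. It shows that, on the core of compound 1, a group with no ring can stand here with no change beyond the scatter, though no evidence at hand gives a reason for this.

Going by these compounds, whether an amine, a carboxylic acid or a longer chain at this position would shift the number beyond the scatter remains open. Also open, on these data alone, is whether tert-butyl and phenyl would still read alike with trifluoromethyl in place of the nitro group on the core.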